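The compounds below may be only part of what the source reports. "The series", "measured", "known", "first", "only" and "open" are said of these compounds alone.

Measured in a functional assay on HL-60 cells (Homo sapiens) for inhibition, read by MTT assay, with a stated time of 72 h; a lower number here means a stronger inhibitor, a higher number a weaker inhibitor:

- Compound 1 `CCOc1cccc(N2CCN(C(=O)c3oc(C)nc3-c3ccccc3)CC2)c1`: 151 nM
- Compound 2 `Cc1nc(-c2ccccc2)c(C(=O)N2CCN(c3cc(Cl)cc(Cl)c3)CC2)o1`: 41.8 nM

Of these two values, compound 2 has the lower number, at 41.8 nM, which makes it the stronger inhibitor of the pair. The next compound, compound 3 `Cc1nc(-c2ccccc2)c(C(=O)N2CCN(c3ccccc3F)CC2)o1`, keeps the shared core and changes one group: 2-fluorophenyl in place of 3,5-dichlorophenyl on an amine nitrogen in a ring.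

Going by the values given here, only one measured step bears on this change, as it alters the group at the same place. This is a 3.6-fold lower number from compound 1 to compound 2 (0.56 log units; beyond the scatter), where 3,5-dichlorophenyl replaced 3-ethoxyphenyl. Among the compounds with values here, one step shows no pattern, and no compound carrying 2-fluorophenyl has been measured, so any forecast is rough. Within the data shown here, compound 2 is the lowest value so far, and the only other group tried here, in compound 1, gave 151 nM. Leaving 3,5-dichlorophenyl is therefore expected to raise the number by a modest amount, similar in size to that one step.

The expected change in this assay is a 3.1-fold higher number from compound 2 to compound 3 (0.49 log units; beyond the scatter). For compound 3 the estimate is 130 nM, with an expected range of 45 nM to 400 nM.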

Compound 3, half-maximal inhibitory concentration: 147 nM
Estimate against measurement, compound 3: 1.1-fold (0.05 log units) below; the measured number falls inside the stated range.
By their numbers in this assay, from the lowest: compound 2; then compounds 3 and 1 (each within the scatter of the next).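

In this assay the change from 3,5-dichlorophenyl to 2-fluorophenyl gives a 3.5-fold higher number from compound 2 to compound 3 (0.55 log units; beyond the scatter) and so shows that the 3,5-dichlorophenyl group now stands apart from two different replacements on this amine nitrogen, not from just one. Those two replacements cannot be told apart: 2-fluorophenyl in place of 3-ethoxyphenyl gives a 1.0-fold lower number from compound 1 to compound 3 (0.01 log units; within the scatter) even though the two groups carry different substituents on the phenyl ring. Nothing measured here explains why the numbers fall this way.

The step from 3,5-dichlorophenyl to 2-fluorophenyl alters the kind of halogen, the number of halogen atoms and their placement on the phenyl ring all at once, so the compounds shown leave open which of these matters in this assay. A phenyl ring with no substituent, or a phenyl ring carrying a single chlorine, on the same nitrogen would begin to pull these apart.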